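The source may hold more compounds than are shown below. What is called first, only, known or untested is meant among the compounds shown, and "the series" means these compounds.

Measured compounds:
compound 1 `CN(C(=O)NC(=O)c1ccccc1F)c1nc(C(F)(F)F)c(C(=O)N/N=C/c2ccccc2C(F)(F)F)s1` — 6.32 ug/mL
compound 2 `Cc1nc(N(C)C(=O)NC(=O)c2c(F)cccc2F)sc1C(=O)N/N=C/c1ccccc1C(F)(F)F` — 5.43 ug/mL
compound 3 `CN(C(=O)NC(=O)c1c(F)cccc1F)c1nc(C(F)(F)F)c(C(=O)N/N=C/c2ccc(C(F)(F)F)cc2)s1` — 40.1 ug/mL

In a functional assay on A549 cells (Homo sapiens) for inhibition, read by MTT assay, with a stated time of 72 h (a higher number here means a weaker inhibitor, a lower number a stronger inhibitor), compound 3 gives 40.1 ug/mL, the highest of the three numbers and therefore the weakest inhibitor here; its gap to compound 1 and to compound 2 is in both cases beyond the scatter. Compound 1 and compound 2, which both carry the 2-(trifluoromethyl)phenyl on a carbon with a double bond to nitrogen, give numbers that lie within the scatter of each other, so no order between them is claimed.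

Compound 4 `CN(C(=O)NC(=O)c1c(F)cccc1F)c1nc(C(F)(F)F)c(C(=O)N/N=C/c2ccccc2C(F)(F)F)s1` is not yet measured in this assay. It differs from compound 3 in one place: 2-(trifluoromethyl)phenyl in place of 4-(trifluoromethyl)phenyl on a carbon with a double bond to nitrogen. This is the same arrangement of the trifluoromethylphenyl that compound 1 and compound 2 show, so the step is expected to be a clear move downward, well beyond the scatter, landing near the values of compound 1 and compound 2. The expected step from compound 3 to compound 4 is a 6.2-fold lower number from compound 3 to compound 4 (0.79 log units; beyond the scatter). Compound 4 is thus estimated at 6.5 ug/mL, with a range of 3 ug/mL to 15 ug/mL.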

Compound 4, half-maximal inhibitory concentration: 17.9 ug/mL
Compound 4: the middle estimate sits 2.8-fold (0.44 log units) below what was measured; measured number above the stated range.
By their numbers in this assay, from the lowest: compounds 2 and 1 (each within the scatter of the next); then compound 4; then compound 3.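

In this assay, 2-(trifluoromethyl)phenyl in place of 4-(trifluoromethyl)phenyl on a carbon with a double bond to nitrogen gives a 2.2-fold lower number from compound 3 to compound 4 (0.35 log units; beyond the scatter) in a single-place comparison, so this change alone moves the number, though only modestly. With 2-(trifluoromethyl)phenyl held constant, two other single-place changes also register: trifluoromethyl in place of methyl on an aromatic carbon gives a 3.3-fold higher number from compound 2 to compound 4 (0.52 log units; beyond the scatter) and fluoro in place of hydrogen on an aromatic carbon gives a 2.8-fold higher number from compound 1 to compound 4 (0.45 log units; beyond the scatter) so the value at this position depends on the rest of the molecule's substitution as well. No measured data shown here explain these steps.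

The compounds shown leave open how an unsubstituted phenyl or a pyridine would read at this place. Among these compounds, also open is whether the step seen here keeps its size when the methyl of compound 2 or the single fluoro of compound 1 is present.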